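The source may report more compounds than this note shows. Statements on the series, on what has been measured and on what is new or still open speak of the compounds shown alone.

In an ADME assay on microsomes (Homo sapiens) for metabolic stability (a lower number here means slower removal, a higher number faster removal of the compound), compound 1 `CNC(=O)[C@@H]1CCCN1S(=O)(=O)c1cccc(COc2cccc3c(C(F)(F)F)cc(C)nc23)c1` gives 50 mL/min/kg, while compound 2 `COC[C@@H]1CCCN1S(=O)(=O)c1ccc(Cl)c(COc2cccc3c(C(F)(F)F)cc(C)nc23)c1Cl` gives 450 mL/min/kg, the higher of the two numbers and beyond the scatter. Compound 3 `Cc1cc(C(F)(F)F)c2cccc(OCc3c(Cl)ccc(S(=O)(=O)N4C[C@@H](C)O[C@@H](C)C4)c3Cl)c2n1` differs from compound 2 at one place, on a sulfonyl sulfur: 2,6-dimethylmorpholin-4-yl in place of 2-(methoxymethyl)pyrrolidin-1-yl on a sulfonyl sulfur. Among the measured compounds shown here, no measured pair isolates this change, so the expectation starts from compound 2 at 450 mL/min/kg. A small fall in this assay is expected, with the estimate a 1.5-fold lower number from compound 2 to compound 3 (0.18 log units; within the scatter), which stays within the scatter. For compound 3 the estimated clearance is 300 mL/min/kg, with an expected range of 120 mL/min/kg to 650 mL/min/kg.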

Compound 3, clearance: 317 mL/min/kg
Estimate against measurement, compound 3: 1.1-fold (0.02 log units) below; low and high end bracket the measured number.
By their numbers in this assay, from the lowest: compound 1; then compounds 3 and 2 (each within the scatter of the next).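

In this assay, 2,6-dimethylmorpholin-4-yl in place of 2-(methoxymethyl)pyrrolidin-1-yl on a sulfonyl sulfur gives a 1.4-fold lower number from compound 2 to compound 3 (0.15 log units; within the scatter). This first one-place pair at the position shows that exchanging a five-membered ring for a six-membered ring with a second hetero atom, at equal heavy-atom count, does not separate the two compounds. Nothing on hand offers an explanation for this result. Open, on these data alone, is whether an amine or a carboxylic acid on the sulfonyl sulfur would give a step beyond the scatter. Also open, as far as these compounds go, is whether this same exchange reads alike on the core of compound 1.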